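Prenyloxy flavanone series: aryl variation at the saturated ring carbon

This account rests on a few compounds, and the source may have more. Where it says the series, first, only, none or still open, it means among the compounds named here.

Of the compounds shown here, three of the shared core have been measured in a functional assay; on this read-out higher numbers stand for weaker inhibition and lower numbers for stronger inhibition. Compound 1 `CC(C)=CCOc1ccc2c(c1)OC(c1cccc(F)c1)CC2=O` gives 4280 nM, the lowest of the three numbers. Compound 2 `CC(C)=CCOc1ccc2c(c1)OC(c1cccc(Br)c1)CC2=O` gives 5280 nM, and compound 3 `CC(C)=CCOc1ccc2c(c1)OC(c1ccc(Br)cc1)CC2=O` gives 8120 nM. All three lie close together: a 1.2-fold higher number from compound 1 to compound 2 (0.09 log units; within the scatter), a 1.9-fold higher number from compound 1 to compound 3 (0.28 log units; within the scatter) and a 1.5-fold higher number from compound 2 to compound 3 (0.19 log units; within the scatter). The aryl group on the saturated ring carbon has so far been changed only among halogen-bearing phenyls, and none of these changes moved the number beyond the scatter.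

Compound 4 `COc1ccc(C2CC(=O)c3ccc(OCC=C(C)C)cc3O2)cc1` is not yet measured. It differs from compound 1 as follows: 4-methoxyphenyl in place of 3-fluorophenyl on a saturated ring carbon. Within the data shown here, no measured step introduces a methoxy group, so the bearing steps are only the aryl swaps among compounds 1, 2 and 3, each of them within the scatter. On that basis the step from compound 1 to compound 4 is expected to be small, with at most a modest drift toward a higher number, as the swap of 3-fluorophenyl for 4-bromophenyl gave a 1.9-fold higher number from compound 1 to compound 3 (0.28 log units; within the scatter); the expected step is a 1.3-fold higher number from compound 1 to compound 4 (0.11 log units; within the scatter). Compound 4 is therefore estimated at 5500 nM in this assay, with a range from 2500 nM to 12000 nM.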

Compound 4, half-maximal inhibitory concentration: 10200 nM
The estimate for compound 4 lay 1.9-fold (0.27 log units) below the measured number; the range from low to high includes it.
By their numbers in this assay, from the lowest: compounds 1, 2, 3 and 4 (each within the scatter of the next, the first and the last beyond it).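

In this assay, among these compounds, the change to 4-methoxyphenyl on the saturated ring carbon gives the first step that passes the scatter, a 2.4-fold higher number from compound 1 to compound 4 (0.38 log units; beyond the scatter), though only modestly. The other two steps stay within the scatter, a 1.3-fold higher number from compound 3 to compound 4 (0.10 log units; within the scatter) and a 1.9-fold higher number from compound 2 to compound 4 (0.29 log units; within the scatter), so methoxy in place of bromo on an aromatic carbon leaves compound 4 unresolved from compound 3, and compound 4 is likewise unresolved from compound 2. This position therefore now shows that a group other than a halogen is tolerated without a large change in the number, and that only the two ends of the series separate; nothing available explains that separation.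

The step to compound 4 changes both the substituent and its place on the phenyl ring, and the compounds shown do not separate these two contributions. Also open, going by these compounds, is how the number responds to a phenyl bearing an amine or a carboxylic acid at this ring carbon, or to a longer chain in place of the prenyloxy group on the shared core.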